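The source may hold more compounds than are shown below. What is called first, only, known or untested is meant among the compounds shown, and "the series" means these compounds.

Measured compounds:
compound 1, `Oc1ccc(CC[C@H]2CC=C[C@H](c3ccc(O)cc3)O2)cc1`: 45.3 uM
compound 2, `COc1cc(O)c([C@@H]2C[C@H](CCc3ccc(O)cc3)O[C@H](c3ccc(O)cc3)[C@H]2[C@H](/C=C/C[C@@H](O)CCc2ccc(O)cc2)c2ccc(O)cc2)c(O)c1C(=O)/C=C/c1ccc(O)cc1`: 9.02 uM

Both were tested in a functional assay on HT-1080 cells (Homo sapiens) for antiproliferative activity, read by MTT assay; on this read-out lower numbers stand for an effect already at smaller amounts and higher numbers for an effect only at larger amounts of compound. Of the two, compound 1 stands at the higher number: in this assay compound 1 gives 45.3 uM, while compound 2 gives 9.02 uM, a gap that lies beyond the scatter, so compound 2 shows its effect at smaller amounts. For the measured compounds named here, no two measured compounds differ in a single place, so no step between them is known.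

Compound 3, `Oc1ccc(CC[C@H]2CC=C[C@@H](c3ccc(O)cc3)O2)cc1`, has not yet been tested in this assay. It differs from compound 1 as follows: the two compounds have the same atoms and bonds and differ only in configuration as drawn: 1 of 2 stereo elements differ; a stereocentre at a saturated ring carbon is drawn R in compound 1 and S in compound 3

Whether a change of configuration at a saturated ring carbon moves the number cannot be read from the two measured compounds. Without a measured step of this kind, the expected step from compound 1 to compound 3 is none beyond the scatter, a 1.1-fold lower number from compound 1 to compound 3 (0.05 log units; within the scatter). Compound 3 is therefore expected to give about 40 uM, within a range from 15 uM to 110 uM.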

Compound 3, concentration for half-maximal effect: 79.4 uM
Estimate against measurement, compound 3: 2.0-fold (0.30 log units) below, and the stated range covers the measured number.
By their numbers in this assay, from the lowest: compound 2; then compounds 1 and 3 (each within the scatter of the next).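

For the compounds shown here, compounds 1 and 3 are the first pair here that can be compared at a single place, and that comparison is a clean one: the fact that compounds 1 and 3 differ only in the configuration as drawn. In this assay the measured step at this saturated ring carbon is a 1.8-fold higher number from compound 1 to compound 3 (0.24 log units; within the scatter), so the R and S drawings at this stereocentre cannot be told apart on this read-out. For this position on the core of compound 1, the configuration therefore has no effect that can be separated from ordinary measurement variation, something the unrelated pair of compounds 1 and 2 could not show.

Going by these compounds, whether the second stereocentre moves the number stays open, as it is drawn alike in compound 1 and compound 3. Also open, on these data alone, is what an amine or a carboxylic acid in place of a hydroxyl group would do to the number.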